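The source may hold more compounds than are shown below. What is called first, only, known or untested is meant among the compounds shown, and "the series" means these compounds.

Among the measured compounds shown here, compound 3 `OC[C@H]1O[C@@H](n2cnc3c(NCc4ccccc4Br)ncnc32)[C@H](O)[C@@H]1O` stands second highest of the three numbers so far in a functional assay on K562 cells (Homo sapiens) for antiproliferative activity, with a stated time of 72 h; on this read-out higher numbers stand for weaker inhibition and lower numbers for stronger inhibition: compound 3 gives 10000 nM, while compound 1 `OC[C@H]1O[C@@H](n2cnc3c(NCc4ccccc4F)ncnc32)[C@H](O)[C@@H]1O` gives 33200 nM and compound 2 `OC[C@H]1O[C@@H](n2cnc3c(NCc4ccc(F)cc4)ncnc32)[C@H](O)[C@@H]1O` gives 2700 nM. The shift a 3.7-fold higher number from compound 2 to compound 3 (0.57 log units; beyond the scatter) and the shift a 3.3-fold lower number from compound 1 to compound 3 (0.52 log units; beyond the scatter) were both modest, whereas a 12-fold lower number from compound 1 to compound 2 (1.09 log units; beyond the scatter) was large. Compound 4 `OC[C@H]1O[C@@H](n2cnc3c(NCc4cc(O)cc(O)c4)ncnc32)[C@H](O)[C@@H]1O` differs from compound 3 by 3,5-dihydroxyphenyl in place of 2-bromophenyl on a saturated chain carbon bound to a nitrogen on an aromatic ring. For the measured compounds named here, no measured step exchanges a halogen for hydroxyl groups, so the three steps bear only loosely on this change; they show that alterations at this place have moved this assay by modest to large amounts in either direction. The author therefore expects compound 4 to give about 8000 nM, within 2000 nM to 40000 nM, a step of a 1.3-fold lower number from compound 3 to compound 4 (0.10 log units; within the scatter) that may not exceed the scatter.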

Compound 4, half-maximal inhibitory concentration: > 166000 nM
Compound 4: a limit, no number; the forecaster's own chance of this, stated with the estimate: 10%; at least 20-fold (1.31 log units) between middle value and limit.
By their numbers in this assay, from the lowest: compound 2; then compound 3; then compound 1. At a limit, above all of these: compound 4.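

In this assay, compound 4 gives a limit and not a number: the limit of > 166000 nM in this assay, at which 1 of the 4 values shown sits.

Replacing a halogen-bearing phenyl with 3,5-dihydroxyphenyl at this place gives an at least 16-fold higher number from compound 3 to compound 4 (1.22 log units; beyond the scatter) and an at least 61-fold higher number from compound 2 to compound 4 (1.78 log units; beyond the scatter), both large, and an at least 5.0-fold higher number from compound 1 to compound 4 (0.69 log units; beyond the scatter). Among the compounds shown here, the number thus lies higher than for any of the three halogen-bearing compounds, so this change pushes the read-out further upward than the earlier steps showed.

Going by these compounds, the exact size of these steps stays open. So does whether a single hydroxyl or a methoxy group on the phenyl ring would shift the number as far.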